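Esterifying the acid of compound 2: an open question

The source may hold more compounds than are shown below. What is called first, only, known or untested is meant among the compounds shown, and "the series" means these compounds.

Measured so far in a functional assay on the whole organism (strain Sprague-Dawley) for inhibition, with Rattus norvegicus as the target, with a stated time of 10 min; on this read-out lower numbers stand for an effect already at smaller amounts and higher numbers for an effect only at larger amounts of compound:
compound 1 `CCCCCOc1ccccc1-c1ncc(C(=O)O)c(=O)[nH]1` gives 3 mg/kg
compound 2 `CCSc1ccccc1-c1ncc(C(=O)O)c(=O)[nH]1` gives 25 mg/kg

Among the measured compounds shown here, compound 2 stands highest of the two numbers; the only step, an 8.3-fold higher number from compound 1 to compound 2 (0.92 log units; beyond the scatter), is modest but beyond the scatter, and it changes the side group on the aromatic ring, not the acid. Compound 3 `CCOC(=O)c1cnc(-c2ccccc2SCC)[nH]c1=O` differs from compound 2 by ethyl in place of hydrogen on an oxygen next to a carbonyl group. For the measured compounds named here, no measured step touches this part of the molecule, so the data give no direction. For compound 3 the expected step is a 1.2-fold higher number from compound 2 to compound 3 (0.08 log units; within the scatter), within the scatter. Compound 3 is therefore estimated at 30 mg/kg, within 10 mg/kg to 100 mg/kg.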

Compound 3, dose for 50% inhibition: > 5 mg/kg
Compound 3: no number, only a limit; the forecaster's own chance of this, stated with the estimate: 15%; the middle value does not contradict the limit.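

Compound 3 gives only a limit of > 5 mg/kg and not a number. Among the compounds shown here, no step from compound 2 to compound 3 can be read. As far as these compounds go, whether ethyl in place of hydrogen on this oxygen moves the number up or down stays open.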